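Moving the Bromine on the Bromophenyl Ring

A few compounds are considered here, and "the series" means these few. Any claim that something is new, unique, unknown or untested is made for them only; others in the source may bear on it.

Compound 1 `O=C(/C=C\c1ccc([N+](=O)[O-])cc1)N1N=C(c2ccncc2)OC1c1c[nH]c2ccccc12` in an ADME assay on HeLa cells (Homo sapiens) for cytotoxicity, read by MTT assay, with a stated time of 72 h; on this read-out higher numbers stand for weaker inhibition of growth and lower numbers for stronger inhibition of growth: > 30 ug/mL
Compound 2 `O=C(/C=C\c1cccc(Br)c1)N1N=C(c2ccncc2)OC1c1c[nH]c2ccccc12` in this assay: > 30 ug/mL

For compound 2 the reading > 30 ug/mL in this assay is a limit of the assay, not a number. For compound 1 the reading > 30 ug/mL is likewise a limit. Both values sit at the limit of > 30 ug/mL in this assay, at which 2 of the 2 values shown sit, so compound 2 stands where every measured compound stands, at the edge of what the assay reports. Among the compounds with values here, the one measured step, a step that the two limits leave unreadable from compound 1 to compound 2, therefore cannot be read.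

Compound 3 `O=C(/C=C\c1ccc(Br)cc1)N1N=C(c2ccncc2)OC1c1c[nH]c2ccccc12` differs from compound 2 by 4-bromophenyl in place of 3-bromophenyl on a double-bonded chain carbon bound to a double-bonded chain carbon. Within the data shown here, no readable step bears on this change, and the only comparison available ends in two limits. Compound 3 is therefore expected to remain at the limit, estimated at 40 ug/mL with a range from 15 ug/mL to 100 ug/mL. The implied step that the limit leaves unreadable from compound 2 to compound 3 is expected to stay within the scatter.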

Compound 3, concentration for 50% growth inhibition: > 30 ug/mL
Compound 3: no number, only a limit; the forecaster's own chance of this, stated with the estimate: 80%; the middle value does not contradict the limit.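

Compound 3 gives only a limit in this assay, as do compound 1 and compound 2, so no step among the three can be read: the limit of > 30 ug/mL in this assay, at which 3 of the 3 values shown sit.

As far as these compounds go, whether 4-bromophenyl and 3-bromophenyl differ in growth inhibition, and whether bromo differs from nitro, stays open.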